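This account rests on a few compounds, and the source may have more. Where it says the series, first, only, none or still open, it means among the compounds named here.

In a functional assay on cells (leukaemia cell line, Homo sapiens) for inhibition, read by sulforhodamine B assay, with a stated time of 48 h (on this read-out higher numbers stand for weaker inhibition of growth and lower numbers for stronger inhibition of growth), the measured compounds read as follows:

Compound 1 (`O=S(=O)(Nc1cccc(Cl)c1)c1ccc(-c2cnc(C3CC3)o2)cc1`) gives 54200 nM
Compound 2 (`Cc1cc(NS(=O)(=O)c2ccc(-c3cnc(C4CC4)o3)cc2)ccc1Cl`) gives 33400 nM
Compound 3 (`O=S(=O)(Nc1ccc(F)cc1F)c1ccc(-c2cnc(C3CC3)o2)cc1`) gives 66100 nM

The numbers show a 1.6-fold lower number from compound 1 to compound 2 (0.21 log units; within the scatter) and a 1.2-fold higher number from compound 1 to compound 3 (0.09 log units; within the scatter) so compound 1 sits among the three without separation from either. Compound 4 (`O=S(=O)(Nc1cc(F)cc(F)c1)c1ccc(-c2cnc(C3CC3)o2)cc1`) carries 3,5-difluorophenyl in place of 3-chlorophenyl on a sulfonamide nitrogen. Compound 3 also brings in a difluorophenyl group, with a 1.2-fold higher number from compound 1 to compound 3 (0.09 log units; within the scatter) as its result, and the largest gap measured is a 2.0-fold higher number from compound 2 to compound 3 (0.30 log units; within the scatter) so no step beyond the scatter is expected in this assay and no direction can be named. The expected step is a 1.1-fold higher number from compound 1 to compound 4 (0.04 log units; within the scatter) as an estimate only. For compound 4 the estimated value is 60000 nM with an expected range from 30000 nM to 100000 nM in all likelihood.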

Compound 4, concentration for total growth inhibition: 80000 nM
Beside the measured number, compound 4's estimate is 1.3-fold (0.12 log units) below it, within the range that was stated.
By their numbers in this assay, from the lowest: compounds 2, 1, 3 and 4 (each within the scatter of the next, the first and the last beyond it).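

In this assay, 3,5-difluorophenyl on a sulfonamide nitrogen stays within the scatter of 3-chlorophenyl (a 1.5-fold higher number from compound 1 to compound 4 (0.17 log units; within the scatter)) and of 2,4-difluorophenyl (a 1.2-fold higher number from compound 3 to compound 4 (0.08 log units; within the scatter)), so these groups are not told apart here. For the compounds shown here, the only step beyond the scatter so far is modest (a 2.4-fold higher number from compound 2 to compound 4 (0.38 log units; beyond the scatter)), and it separates 4-chloro-3-methylphenyl from 3,5-difluorophenyl alone, as compound 1 and compound 3 remain within the scatter of compound 2. No available evidence gives a cause for this step.

From the compounds shown here alone, whether an amine, a carboxylic acid or a longer chain in place of these phenyl groups would move the number further remains open.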